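Compound 4 Against a Row of Assay Limits

The compounds below may be only part of what the source reports. "The series", "measured", "known", "first", "only" and "open" are said of these compounds alone.

In an ADME assay on SH-SY5Y cells (Homo sapiens) for cytotoxicity, read by MTT assay, with a stated time of 48 h (a higher number here means a weaker inhibitor, a lower number a stronger inhibitor), compound 1 `COc1ccc(C(=O)/C=C/c2ccc(C(=O)O)cc2)c(O)c1` gives > 100000 nM as a limit of the assay. Compound 2 `COc1ccc(C(=O)/C=C/c2ccc(C(=O)N3CCCC3)cc2)c(O)c1` gives > 100000 nM as a limit too. Compound 3 `COc1ccc(C(=O)/C=C/c2ccc(C(=O)N3CCCCC3)cc2)c(O)c1` likewise stands only at a limit of > 100000 nM in this reading. All the data so far rest on the limit of > 100000 nM in this assay, at which 3 of the 3 values shown sit, and nothing firmer. Compound 4 `COc1ccc(C(=O)/C=C/c2ccc(C(=O)Nc3ccccc3OC)cc2)c(O)c1` brings (2-methoxyphenyl)amino in place of piperidin-1-yl on a carbonyl carbon, the change being (2-methoxyphenyl)amino in place of piperidin-1-yl on a carbonyl carbon at the same carbon. The measured changes there are a step that the two limits leave unreadable from compound 2 to compound 3 and a step that the two limits leave unreadable from compound 1 to compound 3 and a step that the two limits leave unreadable from compound 1 to compound 2 so none offers a size. In this assay only a small shift is therefore expected, estimated as a number no higher from compound 3 to compound 4 (the limit leaves the size open) with no firm direction. For compound 4 the estimate is 100000 nM with an expected range of 30000 nM to 200000 nM and another limit is likely.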

Compound 4, half-maximal inhibitory concentration: > 100000 nM
Compound 4: no number, only a limit (the forecaster's own chance of this, stated with the estimate: 70%); the middle value sits exactly at the limit.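

Among the compounds shown here, compound 4 gives only a limit, as do compound 1, compound 2 and compound 3, so no step among them can be read in this assay here, and all rest on one bound: the limit of > 100000 nM in this assay, at which 4 of the 4 values shown sit. The compounds shown leave open whether any change on the carbonyl carbon alters the read-out at all, since none has yet given an actual number.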